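This account rests on a few compounds, and the source may have more. Where it says the series, first, only, none or still open, it means among the compounds named here.

- Compound 1 `O=C(Nc1ccc(F)c(Cl)c1)c1ccc(F)c(S(=O)(=O)N2CCCC(O)CC2)c1`: 29000 nM
- Compound 2 `CN1CCCN(S(=O)(=O)c2cc(C(=O)Nc3ccc(F)c(Cl)c3)ccc2F)CC1=O`: > 100000 nM
- Compound 3 `CC1(O)CCCN(S(=O)(=O)c2cc(C(=O)Nc3ccc(F)c(Cl)c3)ccc2F)CC1`: 11000 nM

These values come from an ADME assay on HepG2 2.2.15 cells (Homo sapiens) for cytotoxicity, read by luminescence, with a stated time of 3 days; on this read-out higher numbers stand for lower toxicity in this test and lower numbers for higher toxicity in this test. The entry for compound 2 is a limit of the assay, not a number. Of the two true numbers, compound 3 has the lower one, and a 2.6-fold lower number from compound 1 to compound 3 (0.42 log units; beyond the scatter) after a methyl replaces a hydrogen on a saturated ring carbon.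

Compound 4 `CC1(O)CCCCN(S(=O)(=O)c2cc(C(=O)Nc3ccc(F)c(Cl)c3)ccc2F)C1` has the same atoms as compound 3, joined differently: 3-hydroxy-3-methylazepan-1-yl in place of 4-hydroxy-4-methylazepan-1-yl on a sulfonyl sulfur. In words, 3-hydroxy-3-methylazepan-1-yl stands in place of 4-hydroxy-4-methylazepan-1-yl on a sulfonyl sulfur.

Among the measured compounds shown here, no measured step makes this exact kind of change. The closest guide is the modest 2.6-fold lower number from compound 1 to compound 3 (0.42 log units; beyond the scatter), which also alters only that substituent. The much larger an at least 9.0-fold lower number from compound 2 to compound 3 (0.95 log units; beyond the scatter) exchanges one ring for a different one and rests on a limit, so it bears less on this case. Only a small change is therefore expected, and the expected step is a 1.3-fold higher number from compound 3 to compound 4 (0.10 log units; within the scatter).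

The estimated value for compound 4 is 14000 nM, with an expected range from 6000 nM to 35000 nM.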

Compound 4, half-maximal cytotoxic concentration: 10000 nM
Compound 4: middle estimate off by 1.4-fold (0.15 log units), on the high side, and the stated range covers the measured number.
By their numbers in this assay, from the lowest: compounds 4 and 3 (each within the scatter of the next); then compound 1. At a limit, above all of these: compound 2.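

Moving the hydroxy and methyl pair from 4-hydroxy-4-methylazepan-1-yl to 3-hydroxy-3-methylazepan-1-yl on the sulfonyl sulfur gives a 1.1-fold lower number from compound 3 to compound 4 (0.04 log units; within the scatter), so in this assay this rearrangement of the same atoms produces no difference that can be told from the scatter. The new isomer also stands apart from the two other rings, with a 2.9-fold lower number from compound 1 to compound 4 (0.46 log units; beyond the scatter) and an at least 10-fold lower number from compound 2 to compound 4 (1.00 log units; beyond the scatter). Compound 2's entry is a limit and not a number, so the second of those steps has no exact size: the limit of > 100000 nM in this assay, at which 1 of the 4 values shown sits.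

The compounds shown leave open how an amine or a carboxylic acid in place of the hydroxy group would read in this assay. They also leave open which part of 4-methyl-3-oxo-1,4-diazepan-1-yl, the carbonyl or the second ring nitrogen, goes with the limit seen for compound 2.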